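A Hydroxyl at the End of the Alkyne Chain

The compounds below may be only part of what the source reports. "The series", "measured", "known", "first", "only" and "open" are said of these compounds alone.

Three measured compounds share one core and differ only in the group on the triple bond. Compound 1 `CC(C)(C)C#Cc1cn([C@H]2C[C@H](O)[C@@H](CO)O2)c(=O)[nH]c1=O` carries a tert-butyl, and in a functional assay on L1210 cells (Mus musculus) (a lower number here means a stronger inhibitor, a higher number a weaker inhibitor), compound 1 gives 287 ug/mL. Compound 2 `CCCCC#Cc1cn([C@H]2C[C@H](O)[C@@H](CO)O2)c(=O)[nH]c1=O` carries a butyl, and in this assay compound 2 gives 1000 ug/mL. Compound 3 `O=c1[nH]c(=O)n([C@H]2C[C@H](O)[C@@H](CO)O2)cc1C#CCO` carries a hydroxymethyl, and in this assay compound 3 reaches only a limit of the assay, > 1000 ug/mL. Among the compounds with values here, compound 2 stands highest of the two numbers; the only other number lies one step away: a 3.5-fold higher number from compound 1 to compound 2 (0.54 log units; beyond the scatter).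

Compound 4 `O=c1[nH]c(=O)n([C@H]2C[C@H](O)[C@@H](CO)O2)cc1C#CCCCO` is not yet measured. It differs from compound 2 as follows: hydroxy in place of methyl on a saturated chain carbon, three bonds along the chain from a triple-bonded carbon.

Within the data shown here, two measured steps bear on this change, since each brings a hydroxy onto the chain at the triple bond: an at least 3.4-fold higher number from compound 1 to compound 3 (0.54 log units; beyond the scatter), and a number no lower from compound 2 to compound 3 (the limit leaves the size open). Both point the same way, towards a higher number, and one of them ends at the limit of > 1000 ug/mL in this assay, at which 1 of the 3 values shown sits, so a rise beyond the scatter is expected for compound 4 as well, with a real chance that only a limit is reported again. The expected step is a 1.8-fold higher number from compound 2 to compound 4 (0.26 log units; within the scatter). Compound 4 is therefore estimated at 1800 ug/mL, within a range from 700 ug/mL to 5000 ug/mL.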

Compound 4, concentration for 50% inhibition: 280 ug/mL
Compound 4: the middle estimate sits 6.4-fold (0.81 log units) above what was measured; measured number below the stated range.
By their numbers in this assay, from the lowest: compounds 4 and 1 (each within the scatter of the next); then compound 2.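

The hydroxy group on the chain does not always push the number up in this assay: placed on a saturated chain carbon, three bonds along the chain from a triple-bonded carbon, it gives a 3.6-fold lower number from compound 2 to compound 4 (0.55 log units; beyond the scatter). Where the hydroxy sits on the chain therefore counts, as 2-hydroxyethyl in place of hydroxy on a saturated chain carbon bound to a triple-bonded carbon gives an at least 3.5-fold lower number from compound 3 to compound 4 (0.55 log units; beyond the scatter), a step whose full size stays open since it starts from a limit: the limit of > 1000 ug/mL in this assay, at which 1 of the 4 values shown sits A branched, oxygen-free group and a straight chain carrying a hydroxy can also give matching results, as the swap of tert-butyl for 3-hydroxypropyl shows with a 1.0-fold lower number from compound 1 to compound 4 (0.01 log units; within the scatter).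

From the compounds shown here alone, what remains open is whether this drop in the number belongs to the hydroxy alone, or whether an amine or a carboxylic acid at the same place on the chain would give a similar one. It is also open how a longer chain ending in a hydroxy, or a 2-hydroxyethyl group, would compare, since only the 3-hydroxypropyl and hydroxymethyl chains are shown here.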